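Trimming an Amide Substituent to 2-Methylcyclopropyl

The source may hold more compounds than are shown below. What is called first, only, known or untested is meant among the compounds shown, and "the series" means these compounds.

In a physicochemical assay for lipophilicity, at pH 7.4 (a lower number here means a more polar compound, a higher number a more lipophilic compound), compound 3 (`CNC(=O)c1cc(C(=O)N[C@H]2[C@@H]3C[C@@H](O)C[C@@H]32)cc2c1OC[C@H]2c1ccccc1`) gives 2.9 and stands second highest of the three measured compounds. Compound 1 (`CNC(=O)c1cc(C(=O)NC2CC2)cc2c1OC[C@H]2c1cccc(OC)c1`) at 3.8 lies higher and compound 2 (`CNC(=O)c1cc(C(=O)N[C@H]2[C@@H]3COC[C@@H]32)cc2c1OC[C@H]2c1ccncc1`) at 1.3 lies lower, both gaps beyond the scatter.

Compound 4 (`CNC(=O)c1cc(C(=O)N[C@H]2C[C@@H]2C)cc2c1OC[C@H]2c1ccccc1`) carries 2-methylcyclopropyl on the amide-type nitrogen, and the change from compound 3 reads a group of 4 heavy atoms (4 carbon; one three-membered non-aromatic ring of carbon only) in place of a group of 7 heavy atoms (6 carbon, 1 oxygen; one three-membered non-aromatic ring of carbon only, one five-membered non-aromatic ring of carbon only), on an amide-type nitrogen with the rest of the structure untouched. The group that leaves has 1 hydrogen-bond donor and 1 hydrogen-bond acceptor, while the one that enters has 0 hydrogen-bond donors and 0 hydrogen-bond acceptors.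

Among the measured compounds shown here, no two measured compounds differ in one place only, so no measured step sets the size of this change. Compound 1 at 3.8 also has a single three-membered non-aromatic ring of carbon only on an amide-type nitrogen, though it differs elsewhere too. A rise beyond the scatter is therefore expected, estimated at a number 0.70 log units higher from compound 3 to compound 4 (beyond the scatter) in this assay terms. For compound 4 the estimated value is 3.6 with 3.2 and 4 as the expected bounds.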

Compound 4, distribution coefficient: 4.5
Estimate against measurement, compound 4: 0.90 log units below, outside the stated range (above it).
By their numbers in this assay, from the lowest: compound 2; then compound 3; then compound 1; then compound 4.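

With compound 4, the amide-type nitrogen gets its first measured change in one place only: in this assay the reading is a number 1.60 log units higher from compound 3 to compound 4 (beyond the scatter), a large step, when 2-methylcyclopropyl replaces the group of 7 heavy atoms with 1 hydrogen-bond donor and 1 hydrogen-bond acceptor. The earlier compounds shown here differ in more than one place, so they could not show that this substituent alone, with the rest of the structure untouched, can move the distribution coefficient this far. No measurement presented here accounts for the size of this step.

As far as these compounds go, whether the same exchange would give a step of this size in the presence of the other groups carried by compound 1 or compound 2 remains open. Also open, from the compounds shown here alone, is where a primary amine or a longer chain such as n-butyl on this amide-type nitrogen would fall in this assay.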